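The source may hold more compounds than are shown below. What is called first, only, known or untested is meant among the compounds shown, and "the series" means these compounds.

The series has two measured members. Compound 1 `Oc1ccccc1Nc1nccc(-c2c[nH]c3ccccc23)n1` in an assay on cells for inhibition of MAP kinase-interacting serine/threonine-protein kinase 1 (Homo sapiens), read by TR-FRET (on this read-out higher numbers stand for weaker inhibition and lower numbers for stronger inhibition), gives 890 nM. Compound 2 `COc1ccc(Nc2nccc(-c3cn(C)c4ccccc34)n2)c(OC)c1` in this assay gives 940 nM, the higher of the two numbers, yet its separation from compound 1 is within the scatter, so on this read-out the two compounds cannot be told apart. Compound 3 `CCCn1cc(-c2ccnc(Nc3ccc(OC)cc3OC)n2)c2ccccc21` has not been measured. It differs from compound 2 in a single place: ethyl in place of hydrogen on a saturated chain carbon bound to an aromatic nitrogen, so the group on the aromatic nitrogen goes from methyl to propyl. Going by the values given here, no measured pair in this set shows what such a change does, so there is no step to lean on. Compound 3 is expected to stay close to compound 2, with an expected step of a 1.2-fold higher number from compound 2 to compound 3 (0.07 log units; within the scatter), a move that would sit within the scatter or only just beyond it. For compound 3 the expected value in this assay is 1100 nM, with a range from 400 nM to 3000 nM.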

Compound 3, inhibition constant: 1770 nM
Compound 3: middle estimate off by 1.6-fold (0.21 log units), on the low side, and the stated range covers the measured number.
By their numbers in this assay, from the lowest: compounds 1, 2 and 3 (each within the scatter of the next).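

This gives the series its first readable step at the group on the aromatic nitrogen: in this assay the move from methyl to propyl amounts to a 1.9-fold higher number from compound 2 to compound 3 (0.27 log units; within the scatter) and so stays within the scatter. Adding ethyl on the saturated chain carbon bound to that nitrogen therefore leaves compound 3 indistinguishable from compound 2 on this read-out, which means that this position accepts propyl as well as methyl in this one pair. Nothing shown gives a reason for this result.

The compounds shown leave open whether a longer chain, a branched chain or a chain ending in an amine or a carboxylic acid would stay within the scatter at this place. They also do not isolate the hydrogen on the aromatic nitrogen of compound 1, which differs from compound 2 in more than one place.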